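A few compounds are considered here, and "the series" means these few. Any claim that something is new, unique, unknown or untested is made for them only; others in the source may bear on it.

Compounds measured in an assay on SK-BR-3 cells for inhibition of Aromatase (Homo sapiens); a higher number here means a weaker inhibitor, a lower number a stronger inhibitor:
compound 1, `COc1ccc(COc2cc([N+](=O)[O-])ccc2N(C)S(C)(=O)=O)cc1`, 470 nM
compound 2, `CN(c1ccc([N+](=O)[O-])cc1OCc1ccc(Br)cc1)S(C)(=O)=O`, 330 nM

For the measured compounds named here, compound 2 stands within the scatter of compound 1, the only other measured compound: the step of a 1.4-fold lower number from compound 1 to compound 2 (0.15 log units; within the scatter) does not exceed the usual spread. Compound 3, `CN(c1ccc([N+](=O)[O-])cc1OCCc1ccccc1)S(C)(=O)=O`, differs from compound 2 by benzyl in place of 4-bromophenyl on a saturated chain carbon bound to an oxygen on an aromatic ring. Going by the values given here, the one measured step concerns a different change on the same aryl group and was small, so it bears only loosely here. Nothing measured points to a step beyond the scatter in this assay, so compound 3 is expected near compound 2. Compound 3 is estimated at 400 nM, between 150 nM and 1100 nM. The expected step is a 1.2-fold higher number from compound 2 to compound 3 (0.08 log units; within the scatter).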

Compound 3, half-maximal inhibitory concentration: 520 nM
For compound 3 the middle estimate is 1.3-fold (0.11 log units) below the measured one; the range from low to high includes it.
By their numbers in this assay, from the lowest: compounds 2, 1 and 3 (each within the scatter of the next).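

In this assay, the change from 4-bromobenzyl to phenethyl gives a 1.6-fold higher number from compound 2 to compound 3 (0.20 log units; within the scatter), and benzyl in place of 4-methoxyphenyl gives a 1.1-fold higher number from compound 1 to compound 3 (0.04 log units; within the scatter). At this position, a phenethyl group without a ring substituent therefore stays within the scatter of both substituted benzyl groups, so the steps now cover the length of the chain as well as the group on the ring. Nothing available accounts for these results.

On these data alone, whether an amine or a carboxylic acid on the aryl group, or a longer chain, would give a step beyond the scatter remains open.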